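The source may hold more compounds than are shown below. What is called first, only, known or untested is meant among the compounds shown, and "the series" means these compounds.

Measured compounds in a toxicity assay on HepG2 cells (Homo sapiens) for inhibition, read by CellTiter-Glo, with a stated time of 48 h; on this read-out lower numbers stand for stronger inhibition and higher numbers for weaker inhibition:

Compound 1 `COc1ccc2nc(C)cc(OCC(=O)Nc3ccc(Br)c(C)c3)c2c1` gives 15900 nM.

Compound 2 `COc1ccc2nc(C)cc(OCC(=O)Nc3ccc(Cl)c(OC)c3)c2c1` gives a value that is a limit of the assay, > 100000 nM.

Compound 3 `COc1ccc2nc(C)cc(OCC(=O)Nc3nccs3)c2c1` likewise gives only a limit of the assay, > 100000 nM.

Compound 3 therefore stands at the limit of > 100000 nM in this assay, at which 2 of the 3 values shown sit, and its position is known only as a limit. Among the measured compounds shown here, the step from the one numbered compound reads an at least 6.2-fold higher number from compound 1 to compound 3 (0.79 log units; beyond the scatter); the parallel step on the same amide-type nitrogen reads an at least 6.2-fold higher number from compound 1 to compound 2 (0.79 log units; beyond the scatter). Between the two limit compounds the step is a step that the two limits leave unreadable from compound 2 to compound 3.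

Compound 4 `COc1ccc2nc(C)cc(OCC(=O)Nc3noc(C)c3C)c2c1` differs from compound 3 by 4,5-dimethyl-1,2-oxazol-3-yl in place of 1,3-thiazol-2-yl on an amide-type nitrogen. For the measured compounds named here, no measured step covers an exchange of one five-membered aromatic ring for another at this position; the only comparisons available are those from compound 1, both of which end at the limit. With compound 3 itself at the limit, the step of a number no higher from compound 3 to compound 4 (the limit leaves the size open) is expected to be none beyond the scatter, and compound 4 is most likely to be reported as a limit again.

Compound 4 is expected at 100000 nM in this assay, within 40000 nM to 250000 nM.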

Compound 4, half-maximal inhibitory concentration: > 100000 nM
Compound 4: no number, only a limit; the forecaster's own chance of this, stated with the estimate: 70%; the middle value lies on the limit itself.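

In this assay compound 4 gives > 100000 nM, which is a limit of the assay and not a number. A second five-membered aromatic ring with two hetero atoms, 4,5-dimethyl-1,2-oxazol-3-yl, on the amide-type nitrogen therefore behaves like 1,3-thiazol-2-yl as far as the read-out can show, and the exchange for the aryl group of compound 1 reads an at least 6.2-fold higher number from compound 1 to compound 4 (0.79 log units; beyond the scatter). Compound 1 is the only one that still gives a number, and the series now gathers at one end of the range: the limit of > 100000 nM in this assay, at which 3 of the 4 values shown sit.

The steps among compound 2, compound 3 and compound 4 cannot be read, so these three stay unordered against one another. Also open, on these data alone, is whether a morpholine or a carboxylic acid in place of the ring on the amide-type nitrogen would give a number at all.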